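A few compounds are considered here, and "the series" means these few. Any claim that something is new, unique, unknown or untested is made for them only; others in the source may bear on it.

Of the compounds shown here, three sharing one core have been measured in a functional assay on NCI-H520 cells (Homo sapiens); a lower number here means a stronger inhibitor of growth, a higher number a weaker inhibitor of growth. Compound 1 `O=S(=O)(/C=C/c1ccc(Cl)c(Cl)c1)Cc1ccc(Nc2ncnc3ccccc23)cc1` gives 32000 nM, compound 2 `O=S(=O)(/C=C/c1ccc(Cl)cc1Cl)Cc1ccc(Nc2ncnc3ccccc23)cc1` gives 12000 nM and compound 3 `O=S(=O)(/C=C/c1ccc(Cl)cc1Cl)Cc1ccc(Nc2ncnc3ccc(Br)cc23)cc1` gives 8000 nM. The position of compound 2 among these numbers is clear on one side only. Exchanging 3,4-dichlorophenyl for 2,4-dichlorophenyl gives a 2.7-fold lower number from compound 1 to compound 2 (0.43 log units; beyond the scatter), whereas bromo in place of hydrogen on an aromatic carbon gives a 1.5-fold lower number from compound 2 to compound 3 (0.18 log units; within the scatter).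

Compound 4 `O=S(=O)(/C=C/c1ccc(Cl)cc1Cl)Cc1ccc(Nc2ncnc3cc(Cl)ccc23)cc1` has not yet been measured. Its structure departs from that of compound 2 by chloro in place of hydrogen on an aromatic carbon, which is chloro in place of hydrogen on an aromatic carbon. Among the measured compounds shown here, the closest precedent is the bromo change, a 1.5-fold lower number from compound 2 to compound 3 (0.18 log units; within the scatter), which is also a single halogen replacing hydrogen on an aromatic carbon, although the halogen differs. The dichlorophenyl change, a 2.7-fold lower number from compound 1 to compound 2 (0.43 log units; beyond the scatter), involves chloro too, but it lies elsewhere in the molecule and is a weaker guide. For the measured compounds named here, no measured compound carries chloro on the shared core. A small shift at most is therefore expected in this assay, towards a lower number if it appears at all. The expected change is a 1.3-fold lower number from compound 2 to compound 4 (0.12 log units; within the scatter). For compound 4 the estimated value is 9000 nM, with an expected range from 4000 nM to 20000 nM.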

Compound 4, concentration for 50% growth inhibition: 76000 nM
Compound 4: middle estimate off by 8.4-fold (0.93 log units), on the low side; measured number above the stated range.
By their numbers in this assay, from the lowest: compounds 3 and 2 (each within the scatter of the next); then compound 1; then compound 4.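

In this assay, adding a single chlorine to this carbon, meta to a fused ring and para to a fused ring, gives a 6.3-fold higher number from compound 2 to compound 4 (0.80 log units; beyond the scatter), so the step moves towards weaker growth inhibition. This shows that the position is not neutral: the earlier halogen step, a 1.5-fold lower number from compound 2 to compound 3 (0.18 log units; within the scatter), gave no sign that one added halogen atom on the fused system could shift the number beyond the scatter, and compounds 3 and 4 differ in both the halogen and its place, so that step cannot serve as a direct guide to this one. Nothing shown here gives a measured reason for the higher number of compound 4.

The compounds shown leave open whether this shift belongs to chloro in particular or to any group on this carbon, since only the one substituent is seen there. A fluoro, a methoxy group or an amine on the same carbon would separate those two readings, and chloro on the carbon that carries bromo in compound 3 would show how much the place alone contributes.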